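The source may hold more compounds than are shown below. What is called first, only, known or untested is meant among the compounds shown, and "the series" means these compounds.

Measured so far:
compound 1, `Cc1cc(O)c(C2=NN(c3ccc(S(N)(=O)=O)cc3)C(c3ccccc3Cl)C2)cc1Cl`: 2190 nM
compound 2, `Cc1cc(O)c(C2=NN(c3ccc(S(N)(=O)=O)cc3)C(/C=C/c3ccccc3)C2)cc1Cl`: 5730 nM

In a functional assay on NCI-H322M cells (Homo sapiens) for antiproliferative activity, with a stated time of 48 h (a lower number here means a stronger inhibitor of growth, a higher number a weaker inhibitor of growth), compound 2 stands highest of the two numbers recorded; its nearest neighbour is compound 1, which gives the lower value. Among the compounds with values here, the single measured step, a 2.6-fold higher number from compound 1 to compound 2 (0.42 log units; beyond the scatter), arose from putting 2-phenylethenyl in place of 2-chlorophenyl on a saturated ring carbon, so an aromatic ring bound directly to that carbon went with the lower number.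

Compound 3, `COc1ccc(C2CC(c3cc(Cl)c(C)cc3O)=NN2c2ccc(S(N)(=O)=O)cc2)c(OC)c1OC`, differs from compound 2 by 2,3,4-trimethoxyphenyl in place of 2-phenylethenyl on a saturated ring carbon. This change returns an aromatic ring to the same saturated ring carbon, reversing the kind of swap seen in the step from compound 1 to compound 2. That step is the only one bearing on the question, and it points to a modest drop in this assay for compound 3 rather than no change. The step expected is a 3.8-fold lower number from compound 2 to compound 3 (0.58 log units; beyond the scatter). Compound 3 is therefore estimated at 1500 nM, within a range from 500 nM to 5000 nM.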

Compound 3, concentration for 50% growth inhibition: 2860 nM
For compound 3 the middle estimate is 1.9-fold (0.28 log units) below the measured one; the range from low to high includes it.
By their numbers in this assay, from the lowest: compounds 1, 3 and 2 (each within the scatter of the next, the first and the last beyond it).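

In this assay, 2,3,4-trimethoxyphenyl in place of 2-chlorophenyl on this saturated ring carbon gives a 1.3-fold higher number from compound 1 to compound 3 (0.12 log units; within the scatter), so these two differently substituted aromatic rings cannot be told apart at this position. In place of 2-phenylethenyl, the same group gives a 2.0-fold lower number from compound 2 to compound 3 (0.30 log units; within the scatter), so compound 3 cannot be separated from compound 2 either, even though compound 1 and compound 2 stand apart; the oxygen atoms of 2,3,4-trimethoxyphenyl thus bring no gain or loss beyond the scatter against either group. Nothing measured here offers an explanation for these numbers.

Whether an aromatic ring bound directly to this carbon goes with a lower number now rests on compound 1 and compound 2 alone, and compound 3 does not settle it. From the compounds shown here alone, what a cyclohexyl group, or a phenyl ring carrying an amine or a carboxylic acid, would do at this carbon remains open.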